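From Propyl to Pent-2-en-1-yl on the Shared Core

The source may hold more compounds than are shown below. What is called first, only, known or untested is meant among the compounds shown, and "the series" means these compounds.

- compound 1 `COc1ccc(C[C@H]2C(=O)N[C@@H](C)C(=O)N(C)[C@H]3Cc4ccc(cc4)Oc4cc(ccc4OC)C[C@@H](C(=O)N[C@H](C)C(=O)N[C@@H](CCCO)C(=O)N2C)N(C)C3=O)cc1`: 174 nM
- compound 2 `COc1ccc(C[C@H]2C(=O)N[C@@H](C)C(=O)N(C)[C@H]3Cc4ccc(cc4)Oc4cc(ccc4OC)C[C@@H](C(=O)N[C@H](C)C(=O)N[C@@H](CCCN=[N+]=[N-])C(=O)N2C)N(C)C3=O)cc1`: 35.5 nM
- compound 3 `CCCN1C(=O)[C@@H](C)NC(=O)[C@@H]2Cc3ccc(OC)c(c3)Oc3ccc(cc3)C[C@@H](C(=O)N2C)N(C)C(=O)[C@H](C)NC(=O)[C@H](Cc2ccc(OC)cc2)N(C)C(=O)[C@@H]1C`: 3.98 nM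

In a functional assay on P388 cells (Mus musculus) for cytotoxicity (on this read-out lower numbers stand for stronger inhibition and higher numbers for weaker inhibition), compound 3 gives 3.98 nM, the lowest of the three numbers. Compound 2 follows at 35.5 nM and compound 1 at 174 nM.

Compound 4 `CC/C=C/CN1C(=O)[C@@H](C)NC(=O)[C@@H]2Cc3ccc(OC)c(c3)Oc3ccc(cc3)C[C@@H](C(=O)N2C)N(C)C(=O)[C@H](C)NC(=O)[C@H](Cc2ccc(OC)cc2)N(C)C(=O)[C@@H]1C` carries but-1-en-1-yl in place of ethyl on a saturated chain carbon bound to an amide-type nitrogen in a ring. The same difference reads as propyl to pent-2-en-1-yl.

Within the data shown here, only one measured step bears on this, and only loosely: a 4.9-fold lower number from compound 1 to compound 2 (0.69 log units; beyond the scatter). That change sits at another place and swaps azido for hydroxy, so it shows that a chain change can matter but gives neither size nor direction here. Among the measured compounds shown here, no measured compound tests a longer chain at this place. In this assay no step beyond the scatter is therefore expected, with a slight lean towards a higher number. The expected outcome is a 1.5-fold higher number from compound 3 to compound 4 (0.18 log units; within the scatter). For compound 4 the estimated value is 6 nM, with an expected range from 2 nM to 20 nM.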

Compound 4, half-maximal inhibitory concentration: 12 nM
Estimate against measurement, compound 4: 2.0-fold (0.30 log units) below; the range from low to high includes it.
By their numbers in this assay, from the lowest: compound 3; then compound 4; then compound 2; then compound 1.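

In this assay, among these compounds, the exchange of ethyl for but-1-en-1-yl on a saturated chain carbon bound to an amide-type nitrogen in a ring gives a 3.0-fold higher number from compound 3 to compound 4 (0.48 log units; beyond the scatter) as the first measured step at this position. The position therefore responds to the chain it carries, though the step is modest and the longer, unsaturated chain stays in the same direction as the slight lean towards a higher number. No measured information is at hand that explains this step.

The change adds carbon and a double bond together, so the compounds shown leave open which of the two goes with the higher number, and a saturated pentyl chain at this place would separate them. They also leave open how a chain ending in an amine or a carboxylic acid would read here.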